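Replacing a bromine with a methoxyphenyl ring on the shared core

The source may report more compounds than this note shows. Statements on the series, on what has been measured and on what is new or still open speak of the compounds shown alone.

Of the compounds shown here, three sharing one core have been measured in a functional assay on NCI-H522 cells (Homo sapiens) for inhibition, read by sulforhodamine B assay, with a stated time of 48 h, tested at 10 uM; on this read-out lower numbers stand for less inhibition and higher numbers for more inhibition at the one concentration tested (going by the name of the read-out). Compound 1 `Brc1cn2ccnc2c(-c2ccc3ncn(C4CCCCC4)c3c2)n1` gives 16.2%. Compound 2 `COc1ccc(-c2cn3ccnc3c(-c3ccc4ncn(C5CCCCC5)c4c3)n2)cc1` gives -20.9%, and compound 3 `c1ccc2c(-c3cn4ccnc4c(-c4ccc5ncn(C6CCCCC6)c5c4)n3)cccc2c1` gives 19.3%. Among these three numbers compound 1 stands second highest: the move a number 3.1 percentage points higher from compound 1 to compound 3 (within the scatter) stays within the scatter, while the move a number 37.1 percentage points lower from compound 1 to compound 2 (beyond the scatter) is a large drop. Compound 4 `COc1ccccc1-c1cn2ccnc2c(-c2ccc3ncn(C4CCCCC4)c3c2)n1` is not yet measured; it differs from compound 1 as follows: 2-methoxyphenyl in place of bromo on an aromatic carbon. The nearest guide is the drop seen in the step of a number 37.1 percentage points lower from compound 1 to compound 2 (beyond the scatter), since both changes bring in a methoxyphenyl ring in the same place. A downward step is therefore expected, estimated as a number 21.2 percentage points lower from compound 1 to compound 4 (beyond the scatter). Compound 4 is expected to give -5%, with a likely range from -30% to 20%.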

Compound 4, a percentage reported as inhibition, at one concentration (the size of the read-out at that concentration, not a potency): 22.2%
The estimate for compound 4 lay 27.2 percentage points below the measured number; measured number above the stated range.
By their numbers in this assay, from the lowest: compound 2; then compounds 1, 3 and 4 (each within the scatter of the next).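

The 2-methoxyphenyl group shows that a methoxyphenyl ring at this carbon need not lower the number: the placing of the methoxy group on that ring separates the two compounds (a number 43.1 percentage points higher from compound 2 to compound 4 (beyond the scatter)). Swapping in 2-methoxyphenyl for bromo (a number 6 percentage points higher from compound 1 to compound 4 (within the scatter)) or for naphthalen-1-yl (a number 2.9 percentage points higher from compound 3 to compound 4 (within the scatter)) leaves the number within the scatter, so among these four compounds only compound 2 stands apart. Nothing available explains this gap between compound 2 and compound 4. Still open, from the compounds shown here alone, is how an amine or a carboxylic acid at this carbon would read, and whether any group here can raise the number beyond the scatter of compound 1.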